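The compounds below may be only part of what the source reports. "The series", "measured", "known", "first", "only" and "open" are said of these compounds alone.

Among the measured compounds shown here, in an ADME assay on Caco-2 cells (Homo sapiens) for permeability, read by LC-MS, with a stated time of 2 h (on this read-out higher numbers stand for higher permeability and lower numbers for lower permeability), only two compounds of this small set have numbers. Compound 3 `Cc1cc(CN(C)C(CC(=O)O)c2ccc(Cl)cc2)ccc1OCCn1c(=O)ccn(C)c1=O` gives 0.6 nm/s, the lower of the two. Compound 1 `Cc1cc(CN(CC2CC2)C(CC(=O)O)c2ccc(Cl)cc2)ccc1OCCN1C(=O)CCC1=O` gives 5.2 nm/s, a higher number by a gap beyond the usual scatter. Compound 2 `Cc1cc(CN(CCC(F)(F)F)C(CC(=O)O)c2ccc(Cl)cc2)ccc1OCCN1C(=O)CCC1=O` offers no number to compare, as its entry reads "not determined" (no result reported).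

The next compound to be tested is compound 4 `Cc1cc(CN(CC2CC2)C(CC(=O)O)c2ccc(Cl)cc2)ccc1OCCn1c(=O)ccn(C)c1=O`, which is built from compound 3 by one structural change: cyclopropyl in place of hydrogen on a saturated chain carbon bound to an amine nitrogen. In words, cyclopropyl takes the place of hydrogen on a saturated chain carbon bound to an amine nitrogen, so methyl becomes cyclopropylmethyl.

For the measured compounds named here, no two measured compounds differ in just one place, so the effect of this change has never been seen on its own. Going by the values given here, the only hint comes from compound 1, which also carries cyclopropylmethyl on the amine nitrogen and gives 5.2 nm/s. A single value is thin support, so the expectation is a moderate rise that goes beyond the scatter, with a wide margin of doubt. The expected change is a 3.3-fold higher number from compound 3 to compound 4 (0.52 log units; beyond the scatter). For compound 4 the estimated value is 2 nm/s, with an expected range from 0.7 nm/s to 6 nm/s.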

Compound 4, apparent permeability: 3.7 nm/s
Compound 4: the middle estimate sits 1.9-fold (0.27 log units) below what was measured, within the range that was stated.
By their numbers in this assay, from the lowest: compound 3; then compounds 4 and 1 (each within the scatter of the next).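

In this assay, replacing methyl with cyclopropylmethyl on the amine nitrogen gives a 6.2-fold higher number from compound 3 to compound 4 (0.79 log units; beyond the scatter) and thus shows this change on its own, with the rest of the structure held the same. The second step replaces a group of 7 heavy atoms, with a five-membered non-aromatic ring, by a group of 9 heavy atoms, with a six-membered aromatic ring, on a saturated chain carbon, two bonds along the chain from an oxygen on an aromatic ring, and gives a 1.4-fold lower number from compound 1 to compound 4 (0.15 log units; within the scatter) so these two groups cannot be told apart on this read-out when cyclopropylmethyl is present. The data offer no independent measurement that could explain either step.

The compounds shown leave open whether the three-membered ring itself matters or whether a plain ethyl or butyl chain on the amine nitrogen would give a similar number. They also leave open whether the methyl to cyclopropylmethyl step would be of similar size with the group of 7 heavy atoms in place, since this step has been read only with the group of 9 heavy atoms.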